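Two aryl swaps on a shared imidazopyrazine-type core

The source may hold more compounds than are shown below. What is called first, only, known or untested is meant among the compounds shown, and "the series" means these compounds.

Measured so far: compound 1 `COc1ccc(-c2cn3ccnc3c(-c3ccc4ncn(C5CCCCC5)c4c3)n2)cc1` gives 71.1% in a functional assay on MDA-MB-231 cells (Homo sapiens) for inhibition, read by sulforhodamine B assay, with a stated time of 48 h, tested at 10 uM; a lower number here means less inhibition, a higher number more inhibition at the concentration tested (going by the name of the read-out); compound 2 `Clc1ccc(-c2cn3ccnc3c(-c3ccc4ncn(C5CCCCC5)c4c3)n2)cc1` gives 15.3%.

Compound 2 stands lowest of the two, the step of a number 55.8 percentage points lower from compound 1 to compound 2 (beyond the scatter) being large and beyond the scatter. Compound 3 `COc1ccccc1-c1cn2ccnc2c(-c2ccc3ncn(C4CCCCC4)c3c2)n1` differs from compound 2 by 2-methoxyphenyl in place of 4-chlorophenyl on an aromatic carbon. Among the measured compounds shown here, the only step that bears on this change is the loss of inhibition with chloro replacing methoxy from compound 1 to compound 2, so a return of a methoxyphenyl, though as 2-methoxyphenyl, is expected to raise inhibition in this assay by roughly a number 34.7 percentage points higher from compound 2 to compound 3 (beyond the scatter). For compound 3 the estimate is 50%, between 20% and 80%.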

Compound 3, a percentage reported as inhibition, at one concentration (the size of the read-out at that concentration, not a potency): 15.9%
Estimate against measurement, compound 3: 34.1 percentage points above, and the stated range ends above it.
By their numbers in this assay, from the lowest: compounds 2 and 3 (each within the scatter of the next); then compound 1.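

In this assay, the methoxy group alone does not carry the inhibition of compound 1: 2-methoxyphenyl in place of 4-methoxyphenyl gives a number 55.2 percentage points lower from compound 1 to compound 3 (beyond the scatter), a large step from a change in where the group sits on the ring. Exchanging 4-chlorophenyl for 2-methoxyphenyl gives a number 0.6 percentage points higher from compound 2 to compound 3 (within the scatter), so these two groups cannot be told apart here. Nothing available explains why only the 4-methoxyphenyl compound stands out. From the compounds shown here alone, whether an amine or a hydroxyl in place of the methoxy group would keep the inhibition of compound 1 remains open.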